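The compounds below may be only part of what the source reports. "The series", "measured", "known", "first", "only" and "open" are said of these compounds alone.

Compound 1 `CC[S+](=N)([O-])CCC(NC(=O)c1ccc(NCc2cnc3nc(N)nc(O)c3n2)cc1)C(=O)O` gives 80.2% in a functional assay on L1210 cells (Mus musculus) for inhibition, tested at 0.5 mM; a higher number here means more inhibition at the concentration tested (going by the name of the read-out), a lower number less inhibition.
Compound 2 `CCC[S+](=N)([O-])CCC(NC(=O)c1ccc(NCc2cnc3nc(N)nc(O)c3n2)cc1)C(=O)O` gives 75.2% in this assay.

The larger of the two measured numbers belongs to compound 1, though the step of a number 5 percentage points lower from compound 1 to compound 2 (within the scatter) lies within the scatter, so the two compounds cannot be told apart. Compound 3 `CS(=O)(=O)CCC(NC(=O)c1ccc(NCc2cnc3nc(N)nc(O)c3n2)cc1)C(=O)O` has not yet been measured. It differs from compound 1 in one place: a group of 4 heavy atoms (1 carbon, 2 oxygen, 1 sulfur; no ring) in place of a group of 5 heavy atoms (2 carbon, 1 nitrogen, 1 oxygen, 1 sulfur; no ring), on a saturated chain carbon, three bonds along the chain from an amide-type nitrogen and a carbonyl carbon. For the measured compounds named here, no measured step touches this part of the chain; the only known step alters a different part and stays within the scatter, so it offers no guide. The expected step is a number 4.2 percentage points lower from compound 1 to compound 3 (within the scatter), nothing beyond the scatter. Compound 3 is estimated at 76%, between 60% and 90%.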

Compound 3, a percentage reported as inhibition, at one concentration (the size of the read-out at that concentration, not a potency): 78.6%
Compound 3: the middle estimate sits 2.6 percentage points below what was measured; the range from low to high includes it.
By their numbers in this assay, from the lowest: compounds 2, 3 and 1 (each within the scatter of the next).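

In this assay methylsulfonyl gives a number 1.6 percentage points lower from compound 1 to compound 3 (within the scatter) and a number 3.4 percentage points higher from compound 2 to compound 3 (within the scatter) at this place, on a saturated chain carbon, three bonds along the chain from an amide-type nitrogen and a carbonyl carbon. The earlier pair changed only the length of a chain on sulfur, whereas this change replaces the whole group, including its one hydrogen-bond donor, and the compounds still cannot be told apart. No supporting measurement explains this result. From the compounds shown here alone, whether an amine or a carboxylic acid at this place would give a step beyond the scatter remains open.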